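This account rests on a few compounds, and the source may have more. Where it says the series, first, only, none or still open, it means among the compounds named here.

Measured in an ADME assay on microsomes from liver (Mus musculus, strain ICR) for metabolic stability, read by LC-MS, using NADPH, with a stated time of 60 min, tested at 0.1 uM; on this read-out higher numbers stand for a more stable compound and lower numbers for a less stable compound:
compound 1 `CC#CCn1c(N2CCC[C@@H](N)C2)cc(=O)n(Cc2ccc(Cl)c(C(=O)O)c2)c1=O` gives 70.7%
compound 2 `CC#CCn1c(N2CCC[C@@H](N)C2)cc(=O)n(Cc2ccc(Br)c(C(=O)OC)c2)c1=O` gives 38.1%
compound 3 `CC#CCn1c(N2CCC[C@@H](N)C2)cc(=O)n(Cc2ccc(F)c(C(=O)O)c2)c1=O` gives 37.5%

Compound 2, at 38.1%, lies within the usual scatter of compound 3, and both stand well short of compound 1. The next compound to be tested, compound 4 `CC#CCn1c(N2CCC[C@@H](N)C2)cc(=O)n(Cc2ccc(Cl)c(C(=O)OC)c2)c1=O`, differs from compound 2 in one place: chloro in place of bromo on an aromatic carbon. In words, this is chloro in place of bromo on an aromatic carbon, ortho to a methoxycarbonyl group and para to a large group.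

Going by the values given here, only one measured step bears on this change. It is also an exchange of one halogen for another on an aromatic carbon, and it gave a number 33.2 percentage points lower from compound 1 to compound 3 (beyond the scatter). That step is large, but it is a weak guide here: it swaps fluoro for chloro, not chloro for bromo, and neither of its compounds carries the methoxycarbonyl group. Among the compounds with values here, no measured pair shows the exchange of bromo and chloro itself. The large size of that one step is therefore not carried over, though it does argue for a wide range. What is expected in this assay is a number 2.9 percentage points higher from compound 2 to compound 4 (within the scatter), which means no clear change is anticipated. For compound 4 the estimated value is 41%, with an expected range from 24% to 60%.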

Compound 4, percent of the compound remaining: 34.4%
Compound 4: the middle estimate sits 6.6 percentage points above what was measured, within the range that was stated.
By their numbers in this assay, from the lowest: compounds 4, 3 and 2 (each within the scatter of the next); then compound 1.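

In this assay, going by these compounds alone, the exchange on this aromatic carbon, ortho to a methoxycarbonyl group and para to a large group, gave a number 3.7 percentage points lower from compound 2 to compound 4 (within the scatter) and so, with the methoxycarbonyl group present, chloro and bromo cannot be told apart on this read-out, whereas the one earlier halogen exchange, fluoro in place of chloro with a carboxylic acid present, was large. With chloro held fixed, the methoxycarbonyl group in place of the carboxylic acid gave a number 36.3 percentage points lower from compound 1 to compound 4 (beyond the scatter) and thus the high number of compound 1 is lost by changing either the halogen or the carboxylic acid, at least among the compounds shown. Nothing available here accounts for either step.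

The compounds shown leave open whether bromo alongside the carboxylic acid would keep the number of compound 1 or fall with fluoro, and so whether the halogen matters only when the carboxylic acid is present. They also leave open how an amide or a nitrile would behave in place of the carboxylic acid, and whether a methyl group or plain hydrogen could stand in place of the halogen on this carbon.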